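From pyrrolidin-2-yl to 1-amino-2-hydroxyethyl on a carbonyl carbon

The source may hold more compounds than are shown below. What is called first, only, known or untested is meant among the compounds shown, and "the series" means these compounds.

In a functional assay on HL-60 cells (Homo sapiens) for antiproliferative activity, read by MTT assay, with a stated time of 72 h (a higher number here means a weaker inhibitor, a lower number a stronger inhibitor), compound 1 `COc1cc(C(=O)c2ccc(-c3csc(N)n3)cc2-n2cncn2)cc(OC)c1OC` gives 4.8 nM, compound 2 `COc1cc(C(=O)c2ccc(-c3csc(NC(=O)CN)n3)cc2-n2cncn2)cc(OC)c1OC` gives 27 nM, and compound 3 `COc1cc(C(=O)c2ccc(-c3csc(NC(=O)[C@@H]4CCCN4)n3)cc2-n2cncn2)cc(OC)c1OC` gives 98 nM, the highest number of the three. Compound 4 `COc1cc(C(=O)c2ccc(-c3csc(NC(=O)[C@@H](N)CO)n3)cc2-n2cncn2)cc(OC)c1OC` carries 1-amino-2-hydroxyethyl in place of pyrrolidin-2-yl on a carbonyl carbon. The closest evidence is a 3.6-fold higher number from compound 2 to compound 3 (0.56 log units; beyond the scatter), the same place with aminomethyl replaced by pyrrolidin-2-yl. The wider steps, a 5.6-fold higher number from compound 1 to compound 2 (0.75 log units; beyond the scatter) and a 20-fold higher number from compound 1 to compound 3 (1.31 log units; beyond the scatter), show that both acyl groups raise the number. The entering group has no ring, as in compound 2 at 27 nM, so a modest move to a lower number is expected in this assay, possibly close to the scatter. The expected change is a 2.2-fold lower number from compound 3 to compound 4 (0.34 log units; beyond the scatter). The estimate for compound 4 is 45 nM, with an expected range of 15 nM to 130 nM.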

Compound 4, half-maximal inhibitory concentration: 81 nM
Compound 4: the middle estimate sits 1.8-fold (0.26 log units) below what was measured; measured number inside the range.
By their numbers in this assay, from the lowest: compound 1; then compound 2; then compounds 4 and 3 (each within the scatter of the next).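

In this assay, replacing pyrrolidin-2-yl with 1-amino-2-hydroxyethyl on the carbonyl carbon gives a 1.2-fold lower number from compound 3 to compound 4 (0.08 log units; within the scatter) and so leaves the two groups level, with or without the ring. Hydroxymethyl on the saturated chain carbon gives a 3.0-fold higher number from compound 2 to compound 4 (0.48 log units; beyond the scatter) even though neither compound has a ring, so the absence of a ring alone does not return the number to that of compound 2. The acyl group on the nitrogen still gives a 17-fold higher number from compound 1 to compound 4 (1.23 log units; beyond the scatter) in this comparison with the free amine.

No measurement shown explains these steps. On these data alone, it remains open whether an acetyl group, which has no amine, or a longer chain on the carbonyl carbon would bring the number closer to that of compound 1.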